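The compounds below may be only part of what the source reports. "The series", "measured", "known", "first", "only" and "open" are said of these compounds alone.

Working notes, series measured in a physicochemical assay for solubility, with a stated time of 18 h, at pH 7.4; a higher number here means a more soluble compound, a lower number a less soluble compound:

- compound 1 `COc1ccc(-c2ccc3c(NCCCNCc4cccc(OC)c4O)ccnc3c2)cc1`: 32000 nM
- compound 2 `FC(F)(F)c1ccc(-c2ccc3c(NCCCNCc4ccco4)ccnc3c2)cc1`: 32000 nM
- compound 3 `COc1ccc(Oc2ccc3c(NCCCNCc4cc(F)ccc4OC)ccnc3c2)cc1`: 14500 nM

Compound 1 stands level with compound 2, and together they give the highest number of the three. Compound 3 gives a lower number, and that gap lies beyond the usual scatter.

The next compound is compound 4 `COc1cccc(CNCCCNc2ccnc3cc(Cc4cc(C)cc(C)c4)ccc23)c1O`, which keeps the core of compound 1 and carries 3,5-dimethylbenzyl in place of 4-methoxyphenyl on an aromatic carbon. Among the compounds with values here, no two measured compounds differ in one place only, so no measured step speaks directly to this change. Within the data shown here, the only guide is the narrow spread of values, from compound 3 at 14500 nM to compound 1 at 32000 nM. A small fall in this assay is expected, near the edge of the scatter. The expected step is a 1.8-fold lower number from compound 1 to compound 4 (0.25 log units; within the scatter). For compound 4 the estimated value is 18000 nM, with an expected range from 7000 nM to 35000 nM.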

Compound 4, solubility: 4200 nM
Compound 4: the middle estimate sits 4.3-fold (0.63 log units) above what was measured, outside the stated range (below it).
By their numbers in this assay, from the lowest: compound 4; then compound 3; then compounds 1 and 2 (each within the scatter of the next).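

In this assay, this position on the core of compound 1 responds to the change: 3,5-dimethylbenzyl in place of 4-methoxyphenyl gives a 7.6-fold lower number from compound 1 to compound 4 (0.88 log units; beyond the scatter). Within the data shown here, this is the first single-place step, and it shows that the substituent on this aromatic carbon can move the read-out beyond the scatter. No measurement at hand gives a cause for this step.

A single step cannot separate the benzyl attachment, the two methyl groups and the loss of the methoxy oxygen, so any of these could carry the fall. From the compounds shown here alone, how a morpholine or a carboxylic acid at this same position would read in this assay remains open, as does whether the step would hold on a different side chain.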